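Amino in place of chloro on a weakly cytotoxic compound

This account rests on a few compounds, and the source may have more. Where it says the series, first, only, none or still open, it means among the compounds named here.

Within the data shown here, compound 1 `Fc1cccc(-c2nc(Nc3ccc(Cl)cc3)c3cc(F)ccc3n2)c1` is the only compound with a number in a functional assay on COLO 205 cells (Homo sapiens) for cytotoxicity, read by MTT assay, with a stated time of 48 h (a higher number here means a weaker inhibitor, a lower number a stronger inhibitor), where compound 1 gives 32600 nM. Compound 2 `Oc1ccccc1Nc1nc(-c2cccc(F)c2)nc2ccc(F)cc12` reaches only a limit in this assay, > 50000 nM, namely (the limit of > 50000 nM in this assay, at which 1 of the 2 values shown sits). That step is an at least 1.5-fold higher number from compound 1 to compound 2 (0.18 log units; that floor lies within the scatter). Compound 3 `Nc1ccc(Nc2nc(-c3cccc(F)c3)nc3ccc(F)cc23)cc1` differs from compound 1 by amino in place of chloro on an aromatic carbon. Among the measured compounds shown here, no measured step exchanges chloro for amino; the only step seen replaced the whole 4-chlorophenyl and ended at the limit. The step from compound 1 is therefore expected to be small, if anything toward a weaker number: a 1.4-fold higher number from compound 1 to compound 3 (0.14 log units; within the scatter). Compound 3 is expected to give 45000 nM, between 15000 nM and 150000 nM.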

Compound 3, half-maximal inhibitory concentration: > 50000 nM
Compound 3 ended at the assay's limit; the forecaster's own chance of this, stated with the estimate: 40%; middle value at least 1.1-fold (0.04 log units) from the limit.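

Exchanging chloro for amino on this aromatic carbon, with the rest of the 4-chlorophenyl kept, gives an at least 1.5-fold higher number from compound 1 to compound 3 (0.18 log units; that floor lies within the scatter). Among these compounds, compound 3 thus stands at a limit and not at a number, so a change far smaller than the one to compound 2 also leaves no readable value in this assay: the limit of > 50000 nM in this assay, at which 2 of the 3 values shown sit. The step from compound 2 to compound 3 cannot be read, since both ends are limits. As far as these compounds go, whether a hydroxyl, a methoxy or a carboxylic acid on this carbon would give a number in this assay stays open.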